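Swapping the pendant aryl for pyridin-3-yl in compound 4

The source may hold more compounds than are shown below. What is called first, only, known or untested is meant among the compounds shown, and "the series" means these compounds.

Compound 1 `COc1ccc(-c2nc(/C=C/c3cc4ccccc4nc3OC)no2)cc1` has been measured in an ADME assay on HepG2 cells (Homo sapiens) for cytotoxicity, read by sulforhodamine B assay, with a stated time of 48 h (a higher number here means that more compound is tolerated, a lower number that less compound is tolerated), where compound 1 gives > 220000 nM, a limit of the assay rather than a number. Compound 2 `COc1nc2ccccc2cc1/C=C/c1noc(-c2cccc(Cl)c2)n1` gives > 220000 nM in this assay, again a limit. Compound 3 `COc1nc2ccccc2cc1/C=C/c1noc(COc2ccccc2)n1` likewise gives > 220000 nM, also a limit. The step from compound 1 to compound 2 is a step that the two limits leave unreadable from compound 1 to compound 2, and the step from compound 1 to compound 3 is a step that the two limits leave unreadable from compound 1 to compound 3; both are unreadable on account of the limit of > 220000 nM in this assay, at which 3 of the 3 values shown sit. Compound 4 `COc1nc2ccccc2cc1/C=C/c1noc(-c2cccnc2)n1` differs from compound 1 by pyridin-3-yl in place of 4-methoxyphenyl on an aromatic carbon. Given (the limit of > 220000 nM in this assay, at which 3 of the 3 values shown sit), compound 4 is expected to stay at the limit as well, an expected step that the limit leaves unreadable from compound 1 to compound 4. Compound 4 is therefore estimated at 300000 nM, ranging from 150000 nM to 1000000 nM.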

Compound 4, half-maximal cytotoxic concentration: > 240000 nM
Compound 4 ended at the assay's limit; the forecaster's own chance of this, stated with the estimate: 85%; the middle value lies beyond the limit too.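

The steps from compound 1, compound 2 and compound 3 to compound 4 cannot be read, as all four values in this assay are limits. The compounds shown leave open whether the group on the shared core changes cytotoxicity at all.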